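This account rests on a few compounds, and the source may have more. Where it says the series, first, only, none or still open, it means among the compounds named here.

Of the compounds shown here, three have so far been measured in an assay on CHO cells for displacement of a labelled ligand from Glucagon receptor (Homo sapiens), read by scintillation proximity assay, with a stated time of 3 h; a higher number here means a weaker inhibitor, a lower number a stronger inhibitor. Compound 1 `CC(c1ccc(C(=O)NCCC(=O)O)cc1)n1nc(-c2cc(Cl)cc(Cl)c2)cc1-c1ccccc1C1CCCCC1` gives 337 nM. Compound 2 `CCCOc1ccc(-c2cc(-c3cc(Cl)cc(Cl)c3)nn2Cc2ccc(C(=O)NCCC(=O)O)cc2)cc1Cl` gives 37.9 nM. Compound 3 `CC(C)c1ccc2cc(-c3cc(-c4cc(Cl)cc(Cl)c4)nn3[C@@H](C)c3ccc(C(=O)NCCC(=O)O)cc3)ccc2c1` gives 4.3 nM, the lowest of the three numbers; its gap to compound 2 and its larger gap to compound 1 both lie beyond the scatter of repeated measurements, so compound 3 stands as the strongest inhibitor of the three in this assay.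

Compound 4 `CCOc1ccc2cc(-c3cc(-c4cc(Cl)cc(Cl)c4)nn3[C@@H](C)c3ccc(C(=O)NCCC(=O)O)cc3)ccc2c1` has not yet been measured. It differs from compound 3 in one place: ethoxy in place of isopropyl on an aromatic carbon. Within the data shown here, no pair of measured compounds shows this exact swap, so there is no measured step to lean on, only the fact that the rest of the molecule, which carries compound 3 to its low number, is kept unchanged.

Given that, the step from compound 3 to compound 4 is expected to be small, at most a modest move toward a weaker inhibitor, a 1.6-fold higher number from compound 3 to compound 4 (0.21 log units; within the scatter). Compound 4 is therefore estimated at 7 nM, with a range from 2 nM to 25 nM in this assay.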

Compound 4, half-maximal inhibitory concentration: 8.1 nM
For compound 4 the middle estimate is 1.2-fold (0.06 log units) below the measured one; low and high end bracket the measured number.
By their numbers in this assay, from the lowest: compounds 3 and 4 (each within the scatter of the next); then compound 2; then compound 1.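

In this assay, putting ethoxy in place of isopropyl gives a 1.9-fold higher number from compound 3 to compound 4 (0.28 log units; within the scatter) and so leaves the two compounds indistinguishable. Among these compounds, this is the first measured pair that differs in one place only, and it shows that this position, on an aromatic carbon of a ring that is part of a fused system and para to a fused ring, accepts either group without a change that can be read, even though ethoxy brings an oxygen and a hydrogen-bond acceptor that isopropyl lacks. No measurement on hand explains why the swap has so little effect.

The compounds shown cover only these two groups at this position, so it remains open whether a shorter group such as methoxy, a longer chain such as butoxy, or an amine or a carboxylic acid placed there would keep the number in the same range. One pair also cannot show whether the same swap would behave alike on a different core, such as the core of compound 1.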